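Working notes: from compound 3 to compound 4

The compounds below may be only part of what the source reports. "The series", "measured", "known", "first", "only" and "open" are said of these compounds alone.

Measured so far in a functional assay on MCF7 cells (Homo sapiens) for inhibition, read by MTT assay, with a stated time of 48 h, tested at 10 uM; on this read-out lower numbers stand for less inhibition of growth and higher numbers for more inhibition of growth at the one concentration tested
- compound 1 (`Cc1cc(=O)c2c(O)cc(O)c([C@H]3CCN(C)C[C@H]3OC(=O)c3ccco3)c2o1`) gives 20%
- compound 2 (`Cc1oc2c([C@H]3CCN(C)C[C@H]3O)c(O)cc(O)c2c(=O)c1C(O)c1ccc([N+](=O)[O-])cc1`) gives 4%
- compound 3 (`Cc1oc2c([C@H]3CCN(C)C[C@H]3O)c(O)cc(O)c2c(=O)c1C(O)c1c(F)cccc1Cl`) gives 41%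

Compound 3 holds the highest of the three numbers in this assay, and both other compounds lie lower beyond the scatter. Next to be read is compound 4 (`Cc1oc2c([C@H]3CCN(C)C[C@H]3O)c(O)cc(O)c2c(=O)c1C(O)c1cccc(Cl)c1Cl`), which carries 2,3-dichlorophenyl in place of 2-chloro-6-fluorophenyl on a saturated chain carbon bound to an aromatic carbon and an oxygen on a saturated carbon.

Going by the values given here, one measured step bears on this place. It is large and beyond the scatter: a number 37 percentage points higher from compound 2 to compound 3 (beyond the scatter), with 2-chloro-6-fluorophenyl in place of 4-nitrophenyl. Compound 1 offers no comparison in one place. That single step shows that the group at this place can move the number, but it gives no direction for the present exchange. Here a chlorine-bearing phenyl replaces another chlorine-bearing phenyl, so a smaller step is expected, though the data hold no direct precedent. The expected change is a number 6 percentage points lower from compound 3 to compound 4 (within the scatter), with no shift beyond the scatter anticipated. The estimated value for compound 4 is 35%, with an expected range from 15% to 55%.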

Compound 4, percent growth inhibition at one concentration: 7%
Beside the measured number, compound 4's estimate is 28 percentage points above it; the measured number lies below the stated range.
By their numbers in this assay, from the lowest: compounds 2 and 4 (each within the scatter of the next); then compound 1; then compound 3.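

In this assay, the group on the saturated chain carbon proves sensitive even to an exchange between two chlorine-bearing phenyl groups of equal heavy-atom count: 2,3-dichlorophenyl in place of 2-chloro-6-fluorophenyl gives a number 34 percentage points lower from compound 3 to compound 4 (beyond the scatter) and thus removes most of the growth inhibition seen with compound 3. Set against 4-nitrophenyl, the same 2,3-dichlorophenyl gives a number 3 percentage points higher from compound 2 to compound 4 (within the scatter), so among the three aryl groups shown only the 2-chloro-6-fluorophenyl of compound 3 stands apart, and compound 4 goes against any reading that a chlorine-bearing phenyl alone carries the higher number. No measurement on hand accounts for the gap between the two halogenated phenyl groups.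

The compounds shown do not separate the loss of the fluorine from the gain of the second chlorine or from the changed arrangement of substituents on the phenyl ring, and they do not show how an unsubstituted phenyl or a methoxyphenyl would read at this place. As far as these compounds go, it also stays open how the series would respond to an amine in place of the hydroxyl on the chain carbon that bears the aryl group.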